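Trifluoromethyl for 2,4-difluorophenyl: expected oral exposure

This account rests on a few compounds, and the source may have more. Where it says the series, first, only, none or still open, it means among the compounds named here.

In an ADME assay on the whole organism (Mus musculus, strain Swiss Webster) for pharmacokinetics, read by LC-MS, at a dose of 50 mg/kg by the oral route (on this read-out lower numbers stand for lower exposure and higher numbers for higher exposure at the dose given), compound 1 `O=C(Nc1ccc(F)c(-c2nc3ncc(-c4ccc(F)cc4F)cc3[nH]2)c1)N1CCCC1` gives 9500 nM. Compound 2 `Cc1nc(C)c(C(=O)Nc2ccc(F)c(-c3nc4ncc(-c5ccccc5Cl)cn4n3)c2)o1` gives 39300 nM, which leaves compound 1 with the lower of the two numbers, and the gap between them lies beyond the usual scatter. These two compounds differ in more than one place, so their gap says nothing about any single change.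

Compound 3 `O=C(Nc1ccc(F)c(-c2nc3ncc(C(F)(F)F)cc3[nH]2)c1)N1CCCC1` keeps the core of compound 1 and carries trifluoromethyl in place of 2,4-difluorophenyl on an aromatic carbon. The swap sits on the six-membered aromatic ring with 1 nitrogen, part of a fused system of two rings.

For the measured compounds named here, no measured step shows what this change does to this assay, so the expectation stays loose. The anchor is compound 1 at 9500 nM. The expected result is a slight rise, no shift beyond the scatter, and the estimated step is a 1.4-fold higher number from compound 1 to compound 3 (0.14 log units; within the scatter). Compound 3 is estimated at 13000 nM, with an expected range from 3500 nM to 45000 nM.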

Compound 3, maximal plasma concentration: 1080 nM
Estimate against measurement, compound 3: 12-fold (1.08 log units) above; measured number outside the range, below it.
By their numbers in this assay, from the lowest: compound 3; then compound 1; then compound 2.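

For the compounds shown here, the step of an 8.8-fold lower number from compound 1 to compound 3 (0.94 log units; beyond the scatter) in this assay is the first single-place reading, and it shows that this aromatic carbon, two atoms from the ring nitrogen, is not a neutral place for change on the shared core. Both groups count alike in hydrogen-bond donors, hydrogen-bond acceptors and net charge, so the step goes with the exchange of 2,4-difluorophenyl, with its 8 heavy atoms and one ring, for trifluoromethyl, with 4 heavy atoms and no ring, although one pair cannot separate the loss of the ring from the change of group. Nothing available bears on the reason for the lower number.

On these data alone, it remains open whether the ring itself carries the higher number of compound 1, or whether its fluorines matter, which an unsubstituted phenyl or a 2-chlorophenyl on the core of compound 1 would address. As far as these compounds go, it is equally open how a small non-aromatic group such as methyl, or an amine such as morpholine, would read at this carbon, and compound 2 cannot help, since it differs from compound 1 in more than one place.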